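The source may report more compounds than this note shows. Statements on the series, on what has been measured and on what is new or still open speak of the compounds shown alone.

Measured compounds:
- compound 1, `COc1ccc([C@@H](C)NC(=O)c2ccc(CC3CCN(Cc4ccc5ccccc5c4)CC3)cc2)cc1`: 40 nM
- compound 2, `CN1CCN(CCCN(c2nc3cc(F)c(F)cc3[nH]2)[C@@H]2CC[C@]3(c4cccc(CN5CCCCC5)c4)C[C@@H]3C2)CC1`: 405 nM
- compound 3, `CN1CCN(CCCN(c2nc3cc(Cl)c(Cl)cc3[nH]2)[C@@H]2CC[C@]3(c4cccc(C#N)c4)C[C@@H]3C2)CC1`: 2.2 nM

In an assay on CHO cells for antagonist activity at melanin-concentrating hormone receptor 1 (Homo sapiens), read by luminescence and calcium flux, with a stated time of 10 min (a higher number here means a weaker inhibitor, a lower number a stronger inhibitor), compound 2 stands highest of the three numbers. Its nearest neighbour is compound 1, whose value is lower by a step beyond the scatter, and compound 3 lies further still, lower by a wide margin. Compound 4, `CN1CCN(CCCN(c2nc3cc(F)c(F)cc3[nH]2)[C@@H]2CC[C@]3(c4cccc(CO)c4)C[C@@H]3C2)CC1`, has not been measured. It differs from compound 2 in one place: hydroxy in place of piperidin-1-yl on a saturated chain carbon bound to an aromatic carbon. Going by the values given here, no step between measured compounds corresponds to this change, so the account rests on the values of the three compounds alone. Compound 4 is expected to stay close to compound 2, with a step of a 1.4-fold lower number from compound 2 to compound 4 (0.13 log units; within the scatter) that need not exceed the scatter. For compound 4 the estimate in this assay is 300 nM, within a range of 80 nM to 1200 nM.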

Compound 4, half-maximal inhibitory concentration: 71 nM
Estimate against measurement, compound 4: 4.2-fold (0.63 log units) above; the measured number lies below the stated range.
By their numbers in this assay, from the lowest: compound 3; then compounds 1 and 4 (each within the scatter of the next); then compound 2.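

In this assay, going by these compounds alone, hydroxy in place of piperidin-1-yl on a saturated chain carbon bound to an aromatic carbon brings a 5.7-fold lower number from compound 2 to compound 4 (0.76 log units; beyond the scatter) and so gives the first one-place comparison at this position. The step is modest but beyond the scatter, and it shows that the piperidine ring is not required here for activity at this level. No measurement shown bears on the reason for this step. The ring is lost and the hydroxy gained in one change, so the two remain unseparated. A methoxy group, a primary amine or a morpholin-4-yl group at this place would tell them apart.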